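The source may hold more compounds than are shown below. What is called first, only, known or untested is meant among the compounds shown, and "the series" means these compounds.

Working notes on cytotoxicity in the series.

Compound 1 `Cc1cccc(C(O)c2cc(Cl)ccc2OCC(=O)Nc2ccc(S(N)(=O)=O)cc2C)c1` gives, in an ADME assay on C8166 cells (Homo sapiens) for cytotoxicity, read by MTT assay (on this read-out lower numbers stand for higher toxicity in this test and higher numbers for lower toxicity in this test), a value of 33200 nM. Compound 2 `Cc1cc(S(N)(=O)=O)ccc1NC(=O)COc1ccc(Cl)cc1C(O)c1cccc([N+](=O)[O-])c1` gives in this assay a value of 36900 nM. Among the measured compounds shown here, the only measured step is a 1.1-fold higher number from compound 1 to compound 2 (0.05 log units; within the scatter), so the two numbers are indistinguishable within the usual scatter.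

For the measured compounds named here, on the numbers so far compound 2 stands as the higher of the two, with compound 1 its nearest neighbour, but that difference lies within the scatter and no order can be read from it.

Compound 3 `Cc1cc(S(N)(=O)=O)ccc1NC(=O)COc1ccc(Cl)cc1C(O)c1ccc(Cl)c(Cl)c1` is not yet measured in this assay. Its difference from compound 2 is 3,4-dichlorophenyl in place of 3-nitrophenyl on a saturated chain carbon bound to an aromatic carbon and an oxygen on a saturated carbon.

Going by the values given here, the one measured step, from compound 1 to compound 2, also swaps the group on the same saturated chain carbon and produced no change beyond the scatter. Among the compounds with values here, the change to compound 3 is of the same kind, a swap of the aryl group on that carbon, and the data give no step that moved this read-out. The expectation for compound 3 is therefore a step of a 1.1-fold lower number from compound 2 to compound 3 (0.05 log units; within the scatter), within the scatter, in no particular direction. The estimate for compound 3 in this assay is 33000 nM, with a range from 14000 nM to 80000 nM.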

Compound 3, half-maximal cytotoxic concentration: 24000 nM
Estimate against measurement, compound 3: 1.4-fold (0.14 log units) above; the range from low to high includes it.
By their numbers in this assay, from the lowest: compounds 3, 1 and 2 (each within the scatter of the next).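

At the saturated chain carbon bound to an aromatic carbon and an oxygen on a saturated carbon, the swap to 3,4-dichlorophenyl in this assay gives a 1.5-fold lower number from compound 2 to compound 3 (0.19 log units; within the scatter) and a 1.4-fold lower number from compound 1 to compound 3 (0.14 log units; within the scatter) and both steps stay within the scatter. Where only one pair could be compared before, three aryl groups can now be set side by side at this position, including 3-nitrophenyl with its 2 hydrogen-bond acceptors and 3,4-dichlorophenyl with 0, and the three compounds cannot be told apart on this read-out. Nothing at hand speaks to the reason for this flat result.

The compounds shown carry only substituted phenyl groups at this position, so it remains open whether an amine, a carboxylic acid or a longer alkyl chain in place of the aryl group would give a step beyond the scatter. Also open, from the compounds shown here alone, is whether replacing the hydroxy on this carbon, or changing the shared core elsewhere, would move this read-out at all.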